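The compounds below may be only part of what the source reports. "The series", "measured", "known", "first", "only" and "open" are said of these compounds alone.

Working notes on the oxindole series.

Compound 3 `COc1ccc2c(c1)c(/C=C1\C(=O)Nc3ccc(S(=O)(=O)N(C)C)cc31)cn2C` gives 80% in an assay on isolated protein for inhibition of serine/threonine-protein kinase Sgk1 (Homo sapiens), tested at 1 uM (a lower number here means a stronger effect, a higher number a weaker effect of the compound at the concentration tested), which places it second highest of the three numbers available. Compound 2 `CN(C)S(=O)(=O)c1ccc2c(c1)/C(=C/c1cn(C)c3ccc(O)cc13)C(=O)N2` is nearest, at 81%, and the change a number 1 percentage points lower from compound 2 to compound 3 (within the scatter) lies within the scatter. Within the data shown here, compound 1 `Cn1cc(/C=C2\C(=O)Nc3ccc(S(N)(=O)=O)cc32)c2ccccc21` is furthest, at 55%; no single-change step links it to compound 3, and its structure differs both on the indole oxygen and on the sulfonyl sulfur.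

Compound 4 `COc1ccc2c(c1)c(/C=C1\C(=O)Nc3ccc(S(N)(=O)=O)cc31)cn2C` differs from compound 3 as follows: amino in place of dimethylamino on a sulfonyl sulfur. Among the measured compounds shown here, no measured step covers this change by itself. For the measured compounds named here, the only evidence is indirect: compound 1 carries the sulfamoyl group and returns a number well below compound 3, while the measured step from compound 2 to compound 3 shows that the substituent on the indole oxygen moves the number only within the scatter, so the gap between compound 1 and compound 3 may rest largely on the sulfonyl change. On that basis, a step of a number 22 percentage points lower from compound 3 to compound 4 (beyond the scatter) towards a lower number is expected for compound 4. The estimate for compound 4 in this assay is 58%, within 42% to 74%.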

Compound 4, a percentage reported as activity, at one concentration (the size of the read-out at that concentration, not a potency): 75%
For compound 4 the middle estimate is 17 percentage points below the measured one, and the stated range ends below it.
By their numbers in this assay, from the lowest: compound 1; then compounds 4, 3 and 2 (each within the scatter of the next).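

In this assay the change on a sulfonyl sulfur, amino in place of dimethylamino, reads as a number 5 percentage points lower from compound 3 to compound 4 (within the scatter), so with the methoxy group kept, this change alone cannot be told apart from repeat measurement noise. The step that does exceed the scatter lies on an aromatic carbon: with the sulfamoyl group held constant, methoxy in place of hydrogen gives a number 20 percentage points higher from compound 1 to compound 4 (beyond the scatter). Nothing on hand bears on the reason for either step.

The compounds shown leave open whether methoxy in place of hydrogen on an aromatic carbon gives a similar step when dimethylsulfamoyl stands in place of sulfamoyl. Also open, on these data alone, is how ethoxy or a longer chain on that aromatic carbon, or a cyclic amine such as morpholine on the sulfonyl sulfur, would read.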